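From piperidin-3-yl to piperidin-4-yl: working notes

The source may hold more compounds than are shown below. What is called first, only, known or untested is meant among the compounds shown, and "the series" means these compounds.

compound 1 `COc1ccc(NC(=O)C2CCCNC2)cc1` gives "not determined" (no result reported)
compound 2 `O=C(Nc1ccc(OCc2ccc(F)cc2)cc1)C1CCCNC1` gives 90000 nM

Among the measured compounds shown here, in a functional assay on a cell-free system (Platelet, plasma, Homo sapiens) for inhibition (on this read-out higher numbers stand for weaker inhibition and lower numbers for stronger inhibition), compound 2 gives 90000 nM as the only number so far, so it cannot yet be ranked. For the measured compounds named here, compound 1 has no numerical result, and no step between measured compounds is available.

Compound 3 `O=C(Nc1ccc(OCc2ccc(F)cc2)cc1)C1CCNCC1` is the next compound to be tested. The change from compound 2 is piperidin-4-yl in place of piperidin-3-yl on a carbonyl carbon and the two compounds have the same atoms, joined differently. Going by the values given here, with no measured precedent for this change, the expected 1.1-fold lower number from compound 2 to compound 3 (0.05 log units; within the scatter) would stay within the usual scatter, and no clear direction is expected. This expectation rests on compound 2 at 90000 nM alone. In this assay compound 3 is estimated at 80000 nM with an expected range from 20000 nM to 250000 nM for repeated measurements.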

Compound 3, half-maximal inhibitory concentration: 93000 nM
Beside the measured number, compound 3's estimate is 1.2-fold (0.07 log units) below it; measured number inside the range.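

In this assay, among the compounds shown here, piperidin-4-yl in place of piperidin-3-yl on a carbonyl carbon gives a 1.0-fold higher number from compound 2 to compound 3 (0.01 log units; within the scatter), the first step that can be read. For the compounds shown here, for this pair, the two piperidine attachments on the carbonyl carbon cannot be told apart on this read-out, and a single pair sets no rule for other compounds. Nothing available here explains this result.

The compounds shown leave open whether a ring of another size, such as pyrrolidin-3-yl, or an open-chain group, such as aminomethyl, on the same carbonyl carbon would give a step beyond the scatter. Also open, from the compounds shown here alone, is whether a substituent on the piperidine nitrogen, such as a methyl group or an acetic acid chain, would separate the piperidin-3-yl and piperidin-4-yl forms.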